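The compounds below may be only part of what the source reports. "The series", "measured", "known", "first", "only" and "open" are said of these compounds alone.

Measured in a functional assay on a cell-free system (Platelet, plasma, Homo sapiens) for inhibition; a higher number here means a weaker inhibitor, a lower number a stronger inhibitor:

Compound 1 `O=C(Nc1cccc(OCc2ccccc2)c1)C1CCCNC1` gives "not determined" (no result reported)
Compound 2 `O=C(Nc1cccc(OCc2ccc(-c3ccccc3)cc2)c1)C1CCCNC1` gives 87000 nM
Compound 3 `O=C(Nc1ccc(OCc2ccc(-c3ccccc3)cc2)cc1)C1CCCNC1` gives "not determined" (no result reported)

Among the measured compounds shown here, compound 2 holds the only number in this small set, so it cannot be ranked against compound 1 or compound 3, neither of which has a result. The next compound to be tested is compound 4 `O=C(Nc1cccc(OCc2ccc(-c3ccccc3)cc2)c1)C1CCNCC1`, which has the same atoms as compound 2, joined differently. The change is piperidin-4-yl in place of piperidin-3-yl on a carbonyl carbon and amounts to piperidin-4-yl in place of piperidin-3-yl on a carbonyl carbon.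

For the measured compounds named here, no measured pair shows what such a change does in this assay, so the data offer no guide to either the size or the direction of the step. The expectation therefore rests on compound 2 at 87000 nM as the sole anchor, and no step beyond the scatter is expected. The expected outcome is a 1.1-fold lower number from compound 2 to compound 4 (0.04 log units; within the scatter) in this estimate. Compound 4 is estimated at 80000 nM with an expected range from 25000 nM to 250000 nM in this assay.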

Compound 4, half-maximal inhibitory concentration: 54000 nM
Compound 4: middle estimate off by 1.5-fold (0.17 log units), on the high side; the range from low to high includes it.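

In this assay, among the compounds shown here, piperidin-4-yl in place of piperidin-3-yl on a carbonyl carbon gives a 1.6-fold lower number from compound 2 to compound 4 (0.21 log units; within the scatter), the first step that can be read at this position. The two isomers therefore cannot be told apart in this assay, so for this pair the point at which the piperidinyl group joins the carbonyl carbon makes no difference beyond the usual scatter. Nothing available bears on why the two read alike.

On these data alone, what stays open is whether a different group on this carbonyl carbon, such as pyrrolidin-3-yl or an open aminoethyl chain, would move the number beyond the scatter. As far as these compounds go, it is also open whether the same exchange of piperidin-3-yl for piperidin-4-yl would read the same way on a different core.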